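Growth inhibition: hydroxy to methyl on the sulfonamide series

This account rests on a few compounds, and the source may have more. Where it says the series, first, only, none or still open, it means among the compounds named here.

compound 1 `O=S(=O)(Nc1ccccc1)c1ccccc1`: > 80000 nM
compound 2 `CN(c1ccccc1)S(=O)(=O)c1ccc(C(C)(C)C)cc1`: 30000 nM
compound 3 `CC(C)(C)c1ccc(S(=O)(=O)Nc2cccc(O)c2)cc1`: 12000 nM

The read-out throughout is a functional assay on A549 cells (Homo sapiens) for inhibition; a higher number here means a weaker inhibitor of growth, a lower number a stronger inhibitor of growth. Compound 1 reads > 80000 nM, which is a limit of the assay and not a number. Of the two numbers in hand, compound 3 holds the lower, at 12000 nM. Its nearest neighbour, compound 2, gives 30000 nM, a gap beyond the scatter.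

The next compound to be measured is compound 4 `Cc1cccc(NS(=O)(=O)c2ccc(C(C)(C)C)cc2)c1`. It turns 3-hydroxyphenyl into 3-methylphenyl, with methyl in place of hydroxy on an aromatic carbon, meta to a large group: methyl in place of hydroxy on an aromatic carbon.

Going by the values given here, no pair of measured compounds differs in one place, so the series offers no direct guide to the size of this change. The only anchor for the expectation is the narrow spread between compound 3 at 12000 nM and compound 2 at 30000 nM. A small move towards a higher number is expected in this assay, but none beyond the scatter. The estimated change is a 1.3-fold higher number from compound 3 to compound 4 (0.12 log units; within the scatter). For compound 4 the expected value is 16000 nM, with an estimated range of 6000 nM to 40000 nM.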

Compound 4, concentration for 50% growth inhibition: 80000 nM
Compound 4: the middle estimate sits 5.0-fold (0.70 log units) below what was measured, and the stated range ends below it.
By their numbers in this assay, from the lowest: compound 3; then compound 2; then compound 4.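

In this assay, going by these compounds alone, the change from 3-hydroxyphenyl to 3-methylphenyl gives a 6.7-fold higher number from compound 3 to compound 4 (0.82 log units; beyond the scatter), the first step between two compounds that differ in one place. It shows that this position is not indifferent to the group it carries: hydroxy, with its hydrogen-bond donor and acceptor, cannot give way to methyl, which has neither, without a loss of growth inhibition, although one pair cannot say which feature of hydroxy accounts for that loss. Compound 4 reads at the same figure as the limit of the assay, so the step may show only as much of the loss as the assay can report: the limit of > 80000 nM in this assay, at which 1 of the 4 values shown sits.

As far as these compounds go, whether the hydrogen-bond counts or some other feature of the group governs the result stays open, and an amine or a methoxy group on the same aromatic carbon would help to separate the two. Compound 1 and compound 2 each differ from compound 3 in more than one place, so neither shows how far the effect of this change carries over to other parts of the shared core.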